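Swapping the benzyl ether of compound 1 for a carbamate

The source may hold more compounds than are shown below. What is called first, only, known or untested is meant among the compounds shown, and "the series" means these compounds.

Three compounds share one core and were tested in a functional assay on PANC-1 cells (Homo sapiens) for inhibition, read by MTT assay, with a stated time of 24 h, tested at 10 uM; a lower number here means less inhibition, a higher number more inhibition at the concentration tested (going by the name of the read-out). Compound 1, `CC(C)=CCC1Cc2c(OCc3ccccc3)cc(=O)n(CCCO)c2CC1(C)C`, gives 11.1% in this assay. Compound 2, `CC(C)=CCC1Cc2c(OCCCNS(=O)(=O)c3ccc(C(F)(F)F)cc3)cc(=O)n(CCCO)c2CC1(C)C`, gives 0%, and compound 3, `CC(C)=CCC1Cc2c(OCCCNS(=O)(=O)c3ccc([N+](=O)[O-])cc3)cc(=O)n(CCCO)c2CC1(C)C`, gives 17.3%. Compound 1 therefore stands second of the three numbers: compound 3 lies within the scatter of it, while compound 2 lies beyond the scatter on the lower side. Going by the values given here, the one step between measured compounds that differ in a single place runs a number 17.3 percentage points higher from compound 2 to compound 3 (beyond the scatter), a change of nitro in place of trifluoromethyl on an aromatic carbon.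

Compound 4, `COc1ccc(NC(=O)Oc2cc(=O)n(CCCO)c3c2CC(CC=C(C)C)C(C)(C)C3)cc1`, is not yet measured. It differs from compound 1 in one place: (4-methoxyphenyl)carbamoyl in place of benzyl on an oxygen on an aromatic ring. Among the compounds with values here, no measured step touches this oxygen on the aromatic ring; the only step available concerns a distant substituent on a sulfonamide-bearing ring, so it gives no guide to the present change. With nothing to point either way, a step no larger than the scatter is expected, and the estimated step is a number 0.9 percentage points higher from compound 1 to compound 4 (within the scatter). Compound 4 is thus expected to show about 12% in this assay, with a range from 0% to 30%.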

Compound 4, a percentage reported as inhibition, at one concentration (the size of the read-out at that concentration, not a potency): 0%
Beside the measured number, compound 4's estimate is 12 percentage points above it; the measured number falls inside the stated range.
By their numbers in this assay, from the lowest: compounds 2 and 4 (each within the scatter of the next); then compounds 1 and 3 (each within the scatter of the next).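

In this assay, going by these compounds alone, the step of a number 11.1 percentage points lower from compound 1 to compound 4 (beyond the scatter) is the first reading at this oxygen on an aromatic ring, and it shows that the group carried there can move the number by more than the scatter. The entering (4-methoxyphenyl)carbamoyl keeps a six-membered aromatic ring of carbon only, as benzyl does, but it also brings a nitrogen, two more oxygens, a hydrogen-bond donor and hydrogen-bond acceptors, so the presence of such a ring alone did not hold the number at the level of compound 1. Nothing measured here says which of these differences lies behind the lower number.

The compounds shown leave open whether the lower number goes with the carbamate link or with the methoxy group on its ring, a question that a phenylcarbamoyl group without the methoxy, or a benzyl group carrying a methoxy, would help to separate. Also open, on these data alone, is whether any group on this oxygen can raise the number above that of compound 1, for instance a short chain ending in an amine or a carboxylic acid.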